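Benzyl swap from compound 1 to compound 4

The source may report more compounds than this note shows. Statements on the series, on what has been measured and on what is new or still open speak of the compounds shown alone.

Measured compounds:
compound 1 `CN(C)Cc1ccc2nc(NC(=O)N/N=C/c3cn(Cc4ccccc4Cl)c4ccccc34)sc2c1` — 1180 nM
compound 2 `CN(C)Cc1ccc2nc(NC(=O)N/N=C3\C(=O)Nc4ccc(Cl)cc43)sc2c1` — "not determined" (no result reported)
compound 3 `CN(C)Cc1ccc2nc(NC(=O)N/N=C3\C(=O)Nc4ccc(F)cc43)sc2c1` — "not determined" (no result reported)

Going by the values given here, compound 1 is the only member of the set with a number in a functional assay on MDA-MB-231 cells (Homo sapiens) for cytotoxicity, read by MTT assay, with a stated time of 72 h; a lower number here means a stronger inhibitor, a higher number a weaker inhibitor; compound 1 gives 1180 nM. Among the compounds with values here, compound 2 gives "not determined" (no result reported) and compound 3 gives "not determined" (no result reported), so no step between measured compounds exists and the scale of change the series can show remains unknown. Compound 4 `Cc1ccc(Cn2cc(/C=N/NC(=O)Nc3nc4ccc(CN(C)C)cc4s3)c3ccccc32)cc1` differs from compound 1 in a single place: 4-methylphenyl in place of 2-chlorophenyl on a saturated chain carbon bound to an aromatic nitrogen. Within the data shown here, with no measured step as a guide, the expected move is a small one, either within the scatter or a modest loss, since the change is one substituent for another of the same size. Compound 4 is therefore estimated at 1500 nM, with a range of 500 nM to 4500 nM, an expected step of a 1.3-fold higher number from compound 1 to compound 4 (0.10 log units; within the scatter).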

Compound 4, half-maximal inhibitory concentration: 1220 nM
Beside the measured number, compound 4's estimate is 1.2-fold (0.09 log units) above it; the range from low to high includes it.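

Going by these compounds alone, this is the first step that can be read: in this assay, 4-methylphenyl in place of 2-chlorophenyl on a saturated chain carbon bound to an aromatic nitrogen gives a 1.0-fold higher number from compound 1 to compound 4 (0.01 log units; within the scatter). At this position, then, a chlorine-bearing ring and a methyl-bearing ring cannot be told apart in this read-out. No measurement shown here accounts for this result.

Still open, on these data alone, is whether a benzyl carrying an amine or a carboxylic acid would move the number. Steps involving compound 2 and compound 3 cannot be read.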